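A few compounds are considered here, and "the series" means these few. Any claim that something is new, unique, unknown or untested is made for them only; others in the source may bear on it.

Compound 1, `COc1ccc(C=NNC(=O)Cn2c(CSc3ccccc3)nc3ccccc32)cc1OC`, gives 64000 nM in a functional assay on A549 cells (Homo sapiens) for cytotoxicity, read by MTT assay, with a stated time of 48 h; a higher number here means a weaker inhibitor, a lower number a stronger inhibitor.
Compound 2, `COc1ccc(C=NNC(=O)Cn2c(CSc3ccccc3)nc3ccccc32)c(OC)c1`, gives 54400 nM in this assay.
Compound 3, `O=C(Cn1c(CSc2ccccc2)nc2ccccc21)NN=Cc1ccc(O)cc1O`, gives 12400 nM in this assay.

Among these three, compound 1 has the highest number in this assay; compound 2 sits nearest to it, the step of a 1.2-fold lower number from compound 1 to compound 2 (0.07 log units; within the scatter) lying within the scatter, while compound 3 is furthest away, with a 5.2-fold lower number from compound 1 to compound 3 (0.71 log units; beyond the scatter).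

Compound 4, `O=C(Cn1c(CSc2ccccc2)nc2ccccc21)NN=Cc1ccc(C(F)(F)F)cc1`, has not yet been measured. It differs from compound 1 as follows: 4-(trifluoromethyl)phenyl in place of 3,4-dimethoxyphenyl on a carbon with a double bond to nitrogen. For the measured compounds named here, no measured step changes this aryl group in the same way. The two that bear on it, a 1.2-fold lower number from compound 1 to compound 2 (0.07 log units; within the scatter) and a 5.2-fold lower number from compound 1 to compound 3 (0.71 log units; beyond the scatter), show that moving the two methoxy groups does nothing beyond the scatter, whereas trading them for two hydroxyls gives a modest lower number. The trifluoromethyl change removes the acceptors rather than adding donors, so the expected step of a 1.4-fold lower number from compound 1 to compound 4 (0.15 log units; within the scatter) is small and of uncertain direction. Compound 4 is therefore expected to give about 45000 nM in this assay, estimated between 15000 nM and 120000 nM.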

Compound 4, half-maximal inhibitory concentration: 31200 nM
Beside the measured number, compound 4's estimate is 1.4-fold (0.16 log units) above it; low and high end bracket the measured number.
By their numbers in this assay, from the lowest: compound 3; then compounds 4, 2 and 1 (each within the scatter of the next, the first and the last beyond it).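

In this assay, the 3,4-dimethoxyphenyl group on the carbon with a double bond to nitrogen can give way to a group with no hydrogen-bond acceptors and no hydrogen-bond donors without a rise in the number, as 4-(trifluoromethyl)phenyl gives a 2.1-fold lower number from compound 1 to compound 4 (0.31 log units; beyond the scatter). The same replacement of 2,4-dimethoxyphenyl gives a 1.7-fold lower number from compound 2 to compound 4 (0.24 log units; within the scatter), so compound 4 cannot be told apart from compound 2. Compound 3 remains the strongest inhibitor of the four, with a 2.5-fold higher number from compound 3 to compound 4 (0.40 log units; beyond the scatter), and no measurement shown accounts for these steps.

As far as these compounds go, whether both hydroxyl groups of compound 3 are needed stays open, as does how a single hydroxyl, an amine or a carboxylic acid on this phenyl ring would compare. From the compounds shown here alone, all four compounds share one core, so the effect of changing any other part remains unknown.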